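Methoxy added to the pyrrolidine of a thioamide urea

A few compounds are considered here, and "the series" means these few. Any claim that something is new, unique, unknown or untested is made for them only; others in the source may bear on it.

Of the compounds shown here, two of a shared core have been measured in an assay on isolated protein with Vasopressin V2 receptor (Homo sapiens) as the target; on this read-out lower numbers stand for an effect already at smaller amounts and higher numbers for an effect only at larger amounts of compound. Compound 1 `CO[C@@H]1C[C@@H](C(=O)N2CCC(N3CCCCC3)CC2)N(C(=O)NCc2ccc(C(=O)N3CCCCc4sccc43)cc2Cl)C1` gives 1200 nM, and compound 2 `CN1CCCN(C(=S)[C@@H]2CCCN2C(=O)NCc2ccc(C(=O)N3CCCCc4sccc43)cc2Cl)CC1` gives 1800 nM. Compound 2 carries the higher of the two numbers, yet its gap to compound 1 lies within the scatter, so no order can be read from them. Compound 3 `CO[C@@H]1C[C@@H](C(=S)N2CCCN(C)CC2)N(C(=O)NCc2ccc(C(=O)N3CCCCc4sccc43)cc2Cl)C1` is obtained from compound 2 by methoxy in place of hydrogen on a saturated ring carbon. Among the compounds with values here, no measured pair isolates this change, so the step from compound 2 to compound 3 is expected to stay within the scatter, in no firm direction. On that basis compound 3 is estimated at 1300 nM, with a range from 500 nM to 3500 nM.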

Compound 3, half-maximal effective concentration: 230 nM
Estimate against measurement, compound 3: 5.7-fold (0.75 log units) above, and the stated range ends above it.
By their numbers in this assay, from the lowest: compound 3; then compounds 1 and 2 (each within the scatter of the next).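

In this assay, within the data shown here, methoxy in place of hydrogen on a saturated ring carbon brings a 7.8-fold lower number from compound 2 to compound 3 (0.89 log units; beyond the scatter) and so gives the first isolated reading of this position, two ring bonds from the ring nitrogen. It shows that, on the thioamide urea, the number responds to this small change by more than the scatter. Nothing at hand gives a reason for the step. Whether the lower number requires methoxy itself stays open, since hydroxyl, fluorine or a longer ethoxy chain on that carbon do not appear among these compounds. Equally open, going by these compounds, is whether the same change would act alike on the other compounds of the shared core.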